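Methoxy position on the styryl arm: compound 3 to compound 4

The source may hold more compounds than are shown below. What is called first, only, known or untested is meant among the compounds shown, and "the series" means these compounds.

Compound 1 `COc1cc2nc(/C=C/c3ccccc3)nc(N3CCC(CCNS(N)(=O)=O)CC3)c2cc1OC` carries the plain phenyl ring; in an assay on cells for inhibition of Ectonucleotide pyrophosphatase/phosphodiesterase family member 1 (Homo sapiens), with a stated time of 60 min (a lower number here means a stronger inhibitor, a higher number a weaker inhibitor), compound 1 gives 1840 nM. Compound 2 `COc1cc2nc(/C=C/c3ccc(F)cc3)nc(N3CCC(CCNS(N)(=O)=O)CC3)c2cc1OC` adds a fluorine, and in this assay compound 2 gives 465 nM, a change of a 4.0-fold lower number from compound 1 to compound 2 (0.60 log units; beyond the scatter). Compound 3 `COc1ccccc1/C=C/c1nc(N2CCC(CCNS(N)(=O)=O)CC2)c2cc(OC)c(OC)cc2n1` carries a methoxy group instead, and in this assay compound 3 gives 302 nM, the lowest of the three numbers, though its gap to compound 2 is within the scatter: a 6.1-fold lower number from compound 1 to compound 3 (0.78 log units; beyond the scatter), whereas a 1.5-fold lower number from compound 2 to compound 3 (0.19 log units; within the scatter).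

Compound 4 `COc1cccc(/C=C/c2nc(N3CCC(CCNS(N)(=O)=O)CC3)c3cc(OC)c(OC)cc3n2)c1` is the next member: 3-methoxyphenyl in place of 2-methoxyphenyl on a double-bonded chain carbon bound to a double-bonded chain carbon. Among the measured compounds shown here, no measured pair moves a methoxy group from one ring position to another, so the bearing steps are indirect. Compound 3 keeps the methoxy-bearing ring, and its number is expected to carry over to compound 4 with no step beyond the scatter, because a 6.1-fold lower number from compound 1 to compound 3 (0.78 log units; beyond the scatter) shows the methoxy itself lowering the number while a 1.5-fold lower number from compound 2 to compound 3 (0.19 log units; within the scatter) shows differently substituted rings sitting within the scatter of each other. The expected step is a 1.4-fold higher number from compound 3 to compound 4 (0.14 log units; within the scatter). Compound 4 is estimated at 420 nM in this assay, within 150 nM to 1200 nM.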

Compound 4, inhibition constant: 101 nM
The estimate for compound 4 lay 4.2-fold (0.62 log units) above the measured number, outside the stated range (below it).
By their numbers in this assay, from the lowest: compound 4; then compounds 3 and 2 (each within the scatter of the next); then compound 1.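

Notes on the styryl arm: in this assay moving the methoxy group, with 3-methoxyphenyl in place of 2-methoxyphenyl, gives a 3.0-fold lower number from compound 3 to compound 4 (0.48 log units; beyond the scatter) and so shows that ring position alone, with the same atoms joined differently, can shift the number beyond the scatter. Among the compounds shown here, the earlier compounds could not separate the 2-methoxyphenyl ring from the 4-fluorophenyl ring, whereas the 3-methoxyphenyl ring gives a 4.6-fold lower number from compound 2 to compound 4 (0.66 log units; beyond the scatter) and, against the plain phenyl ring, an 18-fold lower number from compound 1 to compound 4 (1.26 log units; beyond the scatter) as the largest step so far. No available measurement accounts for this dependence on ring position.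

Fluorine appears only in the 4-fluorophenyl ring, so whether its ring position matters in the same way remains open. Also open, from the compounds shown here alone, is how an amine or a carboxylic acid would compare with the methoxy group on this ring.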